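Reversing One Stereocentre: From Compound 3 to Compound 4

The source may hold more compounds than are shown below. What is called first, only, known or untested is meant among the compounds shown, and "the series" means these compounds.

Of the compounds shown here, three built on a related core have been tested in an ADME assay on MRC5 cells (Homo sapiens) for cytotoxicity, read by fluorescence, with a stated time of 72 h; on this read-out higher numbers stand for weaker inhibition and lower numbers for stronger inhibition. Compound 1 `CC1(COc2ccc(F)cc2)Cn2cc([N+](=O)[O-])nc2O1` returned only a limit of the assay, > 64000 nM. Compound 2 `O=[N+]([O-])c1cn2c(n1)OC(COc1ccc(-c3ccc(OC(F)(F)F)cc3)nc1)C2` likewise returned only a limit, > 64000 nM. Among the measured compounds shown here, compound 3 `O=[N+]([O-])c1cnc2n1C[C@H](COc1ccc(-c3ccc(F)cc3)nc1)O2` gave 54000 nM, the only true number among the three readings. The other two readings therefore offer no exact point of comparison, and the picture so far is defined by the limit of > 64000 nM in this assay, at which 2 of the 3 values shown sit.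

Compound 4 `O=[N+]([O-])c1cnc2n1C[C@@H](COc1ccc(-c3ccc(F)cc3)nc1)O2` has yet to be tested in this assay. Its relation to compound 3 is simple: the two compounds have the same atoms and bonds and differ only in configuration as drawn: 1 of 1 stereo elements differ; a stereocentre at a saturated ring carbon is drawn R in compound 3 and S in compound 4. The two compounds have the same atoms and bonds, and the stereocentre at a saturated ring carbon is drawn R in compound 3 and S in compound 4. For the measured compounds named here, no measured pair in this set shows what such a change in configuration does in this assay, so no shift in either direction can be predicted from the data. The expected step of a 1.0-fold higher number from compound 3 to compound 4 (0.01 log units; within the scatter) is therefore none beyond the scatter, with the estimate anchored on compound 3 at 54000 nM. A reading at the assay limit would also be unsurprising. The estimated value for compound 4 is 55000 nM, with an expected range of 30000 nM to 64000 nM.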

Compound 4, half-maximal inhibitory concentration: 55000 nM
Compound 4: middle estimate and measured number agree at the digits printed, and the stated range covers the measured number.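

In this assay, among the compounds shown here, reversing the stereocentre at a saturated ring carbon gives a 1.0-fold higher number from compound 3 to compound 4 (0.01 log units; within the scatter) and so provides the one step that can be read in this set. Compound 3 and compound 4 both return true numbers rather than limits, so this pair shows something the earlier readings could not: at this position, the R and S forms as drawn cannot be told apart in this assay. The comparison is a clean one, although it rests on a single pair, and its basis is this: the fact that compounds 3 and 4 differ only in the configuration as drawn.

As far as these compounds go, whether the two configurations would also read alike with another group in place of the fluorine, such as an amine or a carboxylic acid, stays open, as this one pair speaks only for the fluorine-bearing compounds. Steps to compound 1 and compound 2 cannot be read, and how far their readings lie from the two true numbers remains unknown, the position of the series at the top of the range being marked only by this: the limit of > 64000 nM in this assay, at which 2 of the 4 values shown sit.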